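This account rests on a few compounds, and the source may have more. Where it says the series, first, only, none or still open, it means among the compounds named here.

Working notes on the series. Of the compounds shown here, two sharing one core have been measured in an assay on Sf9 cells for inhibition of serine/threonine-protein kinase 4 (Homo sapiens), read by luminescence and ADP-Glo, with a stated time of 1 h, in the presence of a further agent that is not named here; a higher number here means a weaker inhibitor, a lower number a stronger inhibitor. Compound 1 `CCCC1C(=O)N(C)c2cnc(Nc3ccc(S(N)(=O)=O)cc3)nc2N1C` gives 206 nM in this assay. Compound 2 `CN1C(=O)C(c2ccc(F)cc2)N(C)c2nc(Nc3ccc(S(N)(=O)=O)cc3)ncc21` gives 1770 nM in this assay, the higher of the two numbers. For the measured compounds named here, the one measured step, an 8.6-fold higher number from compound 1 to compound 2 (0.93 log units; beyond the scatter), is the only change recorded so far, and it moves the number beyond the scatter.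

Compound 3 `CN1C(=O)C(c2cccc(F)c2)N(C)c2nc(Nc3ccc(S(N)(=O)=O)cc3)ncc21` is not yet measured in this assay. It differs from compound 2 by 3-fluorophenyl in place of 4-fluorophenyl on a saturated ring carbon. Going by the values given here, no measured step covers a move of the fluorine around the aromatic ring: the step from compound 1 to compound 2 exchanged a propyl chain for an aromatic ring, which is a different kind of change, and nothing measured separates one fluorophenyl from another. The expectation for compound 3 therefore rests on compound 2 alone, and the step is expected to stay within the scatter, in no set direction: a 1.2-fold lower number from compound 2 to compound 3 (0.07 log units; within the scatter). Compound 3 is estimated at 1500 nM in this assay, with a range from 500 nM to 5000 nM.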

Compound 3, half-maximal inhibitory concentration: 134 nM
Beside the measured number, compound 3's estimate is 11-fold (1.05 log units) above it; measured number below the stated range.
By their numbers in this assay, from the lowest: compounds 3 and 1 (each within the scatter of the next); then compound 2.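

In this assay, moving the fluorine on the aromatic ring at the saturated ring carbon, with the same atoms joined differently, is enough to give a 13-fold lower number from compound 2 to compound 3 (1.12 log units; beyond the scatter), so this position distinguishes 3-fluorophenyl from 4-fluorophenyl, a distinction the earlier pair could not show. The exchange of propyl for 3-fluorophenyl gives a 1.5-fold lower number from compound 1 to compound 3 (0.19 log units; within the scatter), whereas the exchange of propyl for 4-fluorophenyl gave an 8.6-fold higher number from compound 1 to compound 2 (0.93 log units; beyond the scatter), so the higher number of compound 2 does not follow from the presence of a fluorophenyl group at this position as such. No measurement in hand accounts for the difference between the two fluorophenyl groups.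

Still open, going by these compounds, is how much of the result depends on fluorine itself, which a phenyl ring with no fluorine, or a ring with chlorine or a methoxy group in place of the fluorine, would help to settle. Also open, on these data alone, is how far this position tolerates other kinds of group, such as a chain longer than propyl, an amine or a carboxylic acid, and whether the preference for 3-fluorophenyl over 4-fluorophenyl carries over to other assays.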